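A few compounds are considered here, and "the series" means these few. Any claim that something is new, unique, unknown or untested is made for them only; others in the source may bear on it.

Three compounds of the shared core carry a measurement in a functional assay on CNE-2 cells (Homo sapiens) for cytotoxicity, read by MTT assay, with a stated time of 72 h; a lower number here means a stronger inhibitor, a higher number a weaker inhibitor. Compound 1 `O=C(NC(=S)NNc1ncnc2ccccc12)c1ccc(C(F)(F)F)cc1` gives 22500 nM; compound 2 `O=C(NC(=S)NNc1ncnc2ccccc12)c1ccc(F)cc1` gives 2840 nM; compound 3 `COc1cc2ncnc(NNC(=S)NC(=O)c3ccccc3OC)c2cc1OC`, whose core is substituted differently and which carries a 2-methoxyphenyl, gives 8410 nM. Compound 2 stands lowest of the three numbers, with compound 3 nearest to it and compound 1 furthest. Within the data shown here, the only step between compounds differing in one place, a 7.9-fold lower number from compound 1 to compound 2 (0.90 log units; beyond the scatter), comes from fluoro in place of trifluoromethyl on an aromatic carbon.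

Compound 4 `Cc1ccccc1C(=O)NC(=S)NNc1ncnc2ccccc12` is not yet measured. Its difference from compound 2: 2-methylphenyl in place of 4-fluorophenyl on a carbonyl carbon. Among the measured compounds shown here, no measured step covers this exchange of the aryl group directly. For the measured compounds named here, the step to compound 2 shows only that a change on that aryl group can shift this assay by a modest amount, and compound 3, with a 2-methoxyphenyl, gives a higher number than compound 2. For compound 4 the expected step in this assay is therefore a 2.3-fold higher number from compound 2 to compound 4 (0.36 log units; beyond the scatter), towards a higher number. The estimate for compound 4 is 6500 nM, with a range from 1800 nM to 24000 nM.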

Compound 4, half-maximal inhibitory concentration: 5460 nM
Compound 4: the middle estimate sits 1.2-fold (0.08 log units) above what was measured, and the stated range covers the measured number.
By their numbers in this assay, from the lowest: compounds 2, 4 and 3 (each within the scatter of the next, the first and the last beyond it); then compound 1.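

In this assay, 2-methylphenyl in place of 4-fluorophenyl on the carbonyl carbon gives a 1.9-fold higher number from compound 2 to compound 4 (0.28 log units; within the scatter) and so stays within the usual scatter. Among these compounds, this is the first exchange of the whole aryl group, and it shows that a fluorine on that group is not needed to keep the number in this range, whereas the earlier step on the same group, a 7.9-fold lower number from compound 1 to compound 2 (0.90 log units; beyond the scatter), lies beyond the scatter. Nothing measured alongside these numbers offers an explanation for either step.

This single exchange alters both the substituent and its printed place on the ring, so the two contributions cannot be separated. On these data alone, how an unsubstituted phenyl, or a phenyl carrying an amine or a carboxylic acid, would read in this assay remains open.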